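Branching and saturating the alkoxy chain in compound 4

The compounds below may be only part of what the source reports. "The series", "measured", "known", "first", "only" and "open" are said of these compounds alone.

Compound 1 `CCCOc1ccc(C(CC(=O)O)c2ccccc2)cc1`: 4.8 uM
Compound 2 `CCCCOc1ccc(C(CC(=O)O)c2ccccc2)cc1`: 1.2 uM
Compound 3 `C/C=C/COc1ccc(C(CC(=O)O)c2ccccc2)cc1`: 2.71 uM

The three measured compounds share one core and differ only in the chain attached to the oxygen on the aromatic ring. In a functional assay on HEK293 cells for agonist activity at Free fatty acid receptor 1 (Homo sapiens), read by calcium flux (on this read-out lower numbers stand for an effect already at smaller amounts and higher numbers for an effect only at larger amounts of compound), compound 3 stands second highest of the three numbers; its step from compound 1 is a 1.8-fold lower number from compound 1 to compound 3 (0.25 log units; within the scatter), while from compound 2 it is a 2.3-fold higher number from compound 2 to compound 3 (0.35 log units; beyond the scatter).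

Compound 4 `CCC(C)COc1ccc(C(CC(=O)O)c2ccccc2)cc1` has not been measured. It differs from compound 3 as follows: sec-butyl in place of prop-1-en-1-yl on a saturated chain carbon bound to an oxygen on an aromatic ring. Two of the measured steps bear on this. The step of a 4.0-fold lower number from compound 1 to compound 2 (0.60 log units; beyond the scatter) shows that lengthening the saturated chain by one carbon brought a modest gain, and the step of a 2.3-fold higher number from compound 2 to compound 3 (0.35 log units; beyond the scatter) shows that introducing a double bond into a chain of the same length cost a modest amount. Compound 4 reverses that double bond and adds a carbon, so a modest step towards lower numbers is expected, of about a 2.7-fold lower number from compound 3 to compound 4 (0.43 log units; beyond the scatter).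

For compound 4 in this assay the expected value is 1 uM, in a range from 0.4 uM to 2.5 uM.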

Compound 4, concentration for half-maximal effect: 0.3 uM
Estimate against measurement, compound 4: 3.3-fold (0.52 log units) above; the measured number lies below the stated range.
By their numbers in this assay, from the lowest: compound 4; then compound 2; then compounds 3 and 1 (each within the scatter of the next).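

Until now the chain had only been lengthened or given a double bond, and compound 4 adds a branch. In this assay, a methyl in place of hydrogen on a saturated chain carbon bound to two saturated chain carbons gives a 4.0-fold lower number from compound 2 to compound 4 (0.60 log units; beyond the scatter), a step of the same size as the one from lengthening the chain, a 4.0-fold lower number from compound 1 to compound 2 (0.60 log units; beyond the scatter). Together these two gains make up a 16-fold lower number from compound 1 to compound 4 (1.20 log units; beyond the scatter), the only large step in this set, so in the saturated compounds 1, 2 and 4 each added carbon lowers the number. Changing but-2-en-1-yl to 2-methylbutyl gives a 9.0-fold lower number from compound 3 to compound 4 (0.96 log units; beyond the scatter), well beyond the cost of the double bond seen in a 2.3-fold higher number from compound 2 to compound 3 (0.35 log units; beyond the scatter), which suggests that the branch accounts for more of this step than the loss of the double bond does.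

Nothing shown here explains why the branched chain gives the lowest number. Going by these compounds, it remains open whether a longer chain such as hexyl, or a ring such as cyclopentyl at the end of the chain, would lower the number further or reverse the trend.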